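Replacing a pendant aryl with an amino-pyrazole on the shared core

A few compounds are considered here, and "the series" means these few. Any claim that something is new, unique, unknown or untested is made for them only; others in the source may bear on it.

Measured compounds:
compound 1 `Cn1cc(-c2cnc(NCc3c(F)ccc4c3CCO4)c3cn[nH]c(=O)c23)cn1`: 21 mL.min-1.g-1
compound 2 `Cc1ncccc1-c1cnc(NCc2c(F)ccc3c2CCO3)c2cn[nH]c(=O)c12`: 41 mL.min-1.g-1

In an ADME assay on microsomes from liver (Homo sapiens) for metabolic stability, read by LC-MS, using NADPH, with stated times of 5 min and 30 min, tested at 1 uM (on this read-out lower numbers stand for slow clearance and higher numbers for fast clearance), compound 2 gives the higher of the two numbers, but its gap to compound 1 is within the scatter, so the two stand level: a 2.0-fold higher number from compound 1 to compound 2 (0.29 log units; within the scatter). Compound 3 `CN(c1ccn(C)n1)c1cnc(NCc2c(F)ccc3c2CCO3)c2cn[nH]c(=O)c12` is the next step on the same aromatic carbon of the core: methyl(1-methyl-1H-pyrazol-3-yl)amino in place of 2-methylpyridin-3-yl on an aromatic carbon.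

For the measured compounds named here, only one measured step touches this position, and it stayed within the scatter, so there is no sign yet that this carbon is sensitive to what sits on it. Going by the values given here, the group entering compound 3 is of a different kind, an amino-linked five-membered ring rather than a six-membered aromatic ring, and no measured pair shows such a change. Compound 3 is therefore expected to land near compound 2, with the estimated step of a 1.2-fold lower number from compound 2 to compound 3 (0.07 log units; within the scatter) not clearly beyond the scatter. The estimate for compound 3 is 35 mL.min-1.g-1, within a range from 14 mL.min-1.g-1 to 90 mL.min-1.g-1.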

Compound 3, intrinsic clearance in microsomes: 62 mL.min-1.g-1
For compound 3 the middle estimate is 1.8-fold (0.25 log units) below the measured one; the range from low to high includes it.
By their numbers in this assay, from the lowest: compounds 1, 2 and 3 (each within the scatter of the next, the first and the last beyond it).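

In this assay, methyl(1-methyl-1H-pyrazol-3-yl)amino stands level with 2-methylpyridin-3-yl (a 1.5-fold higher number from compound 2 to compound 3 (0.18 log units; within the scatter)), so this change of ring type and link leaves the read-out within the scatter. Set against 1-methyl-1H-pyrazol-4-yl, the same group gives the first step at this aromatic carbon to pass beyond the scatter, though only a modest one (a 3.0-fold higher number from compound 1 to compound 3 (0.47 log units; beyond the scatter)), so this carbon is not wholly indifferent to what sits on it. No measurement is at hand that accounts for this difference.

Compound 3 differs from compound 1 in both the amino link and the pyrazole's point of attachment, and the compounds shown do not separate the two. As far as these compounds go, how a morpholine or a plain dimethylamino group on this carbon would read remains open.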